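A few compounds are considered here, and "the series" means these few. Any claim that something is new, unique, unknown or untested is made for them only; others in the source may bear on it.

Compound 1 `C#CCNC1CCc2c(NCc3cccc(F)c3)cccc21`: in an assay on cells for inhibition of Amine oxidase [flavin-containing] B (Homo sapiens), read by fluorescence and Amplex Red, with stated times of 30 min and 15 min (a higher number here means a weaker inhibitor, a lower number a stronger inhibitor), compound 1 gives 1860 nM.
Compound 2 `C#CCNC1CCc2c(NCc3ccc(F)cc3)cccc21`: in this assay compound 2 gives 980 nM.
Compound 3 `C#CCNC1CCc2c(NCc3cccc(C)c3)cccc21`: in this assay compound 3 gives 710 nM.

Compound 3 holds the lowest number of the three, but its standing is only partly secure: the step of a 1.4-fold lower number from compound 2 to compound 3 (0.14 log units; within the scatter) lies within the scatter, whereas the step of a 2.6-fold lower number from compound 1 to compound 3 (0.42 log units; beyond the scatter) lies beyond it. Only the gap to compound 1 therefore separates compound 3 from its neighbours with any confidence.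

Compound 4 `C#CCNC1CCc2c(NCc3ccc(C)cc3)cccc21` has not yet been measured. It differs from compound 3 in a single respect: 4-methylphenyl in place of 3-methylphenyl on a saturated chain carbon bound to a nitrogen on an aromatic ring. Within the data shown here, the one measured step that bears directly on this change is a 1.9-fold lower number from compound 1 to compound 2 (0.28 log units; within the scatter), in which the fluoro analogues underwent the same shift of a substituent from one place on the phenyl ring to the other; that step stayed within the scatter. On this basis the move from compound 3 to compound 4 is expected to give at most a small lowering of the number, and quite possibly none beyond the scatter, so that compound 4 is estimated to show a 1.4-fold lower number from compound 3 to compound 4 (0.15 log units; within the scatter). Compound 4 is accordingly expected to give about 500 nM in this assay, with a plausible range from 200 nM to 1300 nM.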

Compound 4, half-maximal inhibitory concentration: 250 nM
Beside the measured number, compound 4's estimate is 2.0-fold (0.30 log units) above it, and the stated range covers the measured number.
By their numbers in this assay, from the lowest: compound 4; then compounds 3, 2 and 1 (each within the scatter of the next, the first and the last beyond it).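

In this assay, shifting the methyl group gives a 2.8-fold lower number from compound 3 to compound 4 (0.45 log units; beyond the scatter), so 4-methylphenyl in place of 3-methylphenyl on a saturated chain carbon bound to a nitrogen on an aromatic ring is a change that clears the scatter, which the same shift among the fluoro analogues, at a 1.9-fold lower number from compound 1 to compound 2 (0.28 log units; within the scatter), did not do. With 4-methylphenyl in place of 4-fluorophenyl the result is a 3.9-fold lower number from compound 2 to compound 4 (0.59 log units; beyond the scatter), and changing both the group and its place together gives a 7.4-fold lower number from compound 1 to compound 4 (0.87 log units; beyond the scatter), which leaves compound 4 with the lowest number of the four, its steps to all the others lying beyond the scatter. Methyl in place of fluoro now lowers the number on both substituted phenyl groups by a similar amount, so this change reads consistently wherever the group sits among these compounds: the same change on two cores in this assay, a 2.6-fold lower number (0.42 log units; beyond the scatter) from compound 1 to compound 3 and a 3.9-fold lower number (0.59 log units; beyond the scatter) from compound 2 to compound 4, 1.5-fold (0.18 log units) apart, within the scatter of two such steps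

As far as these compounds go, whether the lowering continues with a larger group, such as 4-ethylphenyl, or with a different one, such as 4-methoxyphenyl or 4-chlorophenyl, remains open. It is also open how an unsubstituted phenyl compares with these four, so the compounds shown do not say how much of the lowering the methyl group itself contributes.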